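Sulfonyl substituent variation: from compound 3 to compound 4

The compounds below may be only part of what the source reports. "The series", "measured", "known", "first", "only" and "open" are said of these compounds alone.

Measured so far in a functional assay on the whole organism (trachea) with Rattus norvegicus as the target; on this read-out higher numbers stand for larger maximal responses and lower numbers for smaller maximal responses:
compound 1 `CCNS(=O)(=O)c1ccc2c(c1)C(n1ccccc1=O)=CC(C)(C)O2` gives 87%
compound 2 `CC1(C)C=C(n2ccccc2=O)c2cc(S(=O)(=O)NCCO)ccc2O1` gives 87.9%
compound 3 `CC(C)NS(=O)(=O)c1ccc2c(c1)C(n1ccccc1=O)=CC(C)(C)O2` gives 94.8%

Compound 3 holds the highest of the three numbers, but its steps to the others are within the scatter: a number 7.8 percentage points higher from compound 1 to compound 3 (within the scatter) and a number 6.9 percentage points higher from compound 2 to compound 3 (within the scatter). The third measured step, a number 0.9 percentage points higher from compound 1 to compound 2 (within the scatter), is likewise within the scatter. The three sulfonamide substituents so far therefore give indistinguishable maximal responses in this assay.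

Compound 4 `CC1(C)C=C(n2ccccc2=O)c2cc(S(=O)(=O)N3CCOCC3)ccc2O1` differs from compound 3 by morpholin-4-yl in place of isopropylamino on a sulfonyl sulfur. For the measured compounds named here, no measured step exchanges an alkylamino group for a cyclic amine on the sulfonyl sulfur; the nearest change, the step from compound 2 to compound 3 on the sulfonamide nitrogen, stayed within the scatter. With all three variations at this position flat, no step beyond the scatter is expected in this assay for compound 4, estimated at 89% with a range from 72% to 100%, corresponding to an expected step of a number 5.8 percentage points lower from compound 3 to compound 4 (within the scatter).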

Compound 4, largest response reached (Emax), in percent of the reference or control that the assay uses: 85.1%
The estimate for compound 4 lay 3.9 percentage points above the measured number; the measured number falls inside the stated range.
By their numbers in this assay, from the lowest: compounds 4, 1, 2 and 3 (each within the scatter of the next).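

Morpholin-4-yl on the sulfonyl sulfur extends the flat picture to a cyclic amine in this assay: all three new steps stay within the scatter (a number 9.7 percentage points lower from compound 3 to compound 4 (within the scatter); a number 2.8 percentage points lower from compound 2 to compound 4 (within the scatter); a number 1.9 percentage points lower from compound 1 to compound 4 (within the scatter)). The exchange takes the group on the sulfonyl sulfur from 1 hydrogen-bond donor in isopropylamino to 0 in morpholin-4-yl and adds a six-membered non-aromatic ring, yet no step beyond the scatter appears, so across these four compounds neither feature separates the maximal responses. No supporting data bear on this result.

Going by these compounds, whether any group at this position moves the response beyond the scatter remains open. A piperazin-1-yl group, a carboxylic acid at the end of the chain or a longer alkyl chain on the sulfonamide nitrogen would test how far the flat picture holds.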